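Swapping trifluoromethyl for phenyl on a shared core

A few compounds are considered here, and "the series" means these few. Any claim that something is new, unique, unknown or untested is made for them only; others in the source may bear on it.

Measured so far:
compound 1 `C/C(=N/O)c1ccc(NC(=O)Cn2nc(C(F)(F)F)nc2N)cc1`: 20.5%
compound 2 `COc1cc(-c2nc(N)n(CC(=O)Nc3ccc(/C(C)=N\O)cc3)n2)cc(OC)c1OC`: 25.7%

Both compounds were tested in a functional assay on OVCAR-8 cells (Homo sapiens) for inhibition, read by sulforhodamine B assay, with a stated time of 48 h, tested at 10 uM; on this read-out lower numbers stand for less inhibition of growth and higher numbers for more inhibition of growth at the one concentration tested. There, compound 1 gives 20.5% and compound 2 gives 25.7%. These two values lie within the usual scatter of each other, so compound 1 stands level with compound 2 and neither can be ranked.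

The next compound, compound 3 `C/C(=N/O)c1ccc(NC(=O)Cn2nc(-c3ccccc3)nc2N)cc1`, has phenyl in place of trifluoromethyl on an aromatic carbon. Going by the values given here, no measured pair shows what this exact change does in this assay, so there is no direct precedent. Among the compounds with values here, with only two values so close together, no large move can be argued for, and none beyond the scatter is expected. The expected change is a number 3.5 percentage points higher from compound 1 to compound 3 (within the scatter). For compound 3 the estimated value is 24%, with an expected range from 8% to 42%.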

Compound 3, percent growth inhibition at one concentration: 15.3%
Compound 3: the middle estimate sits 8.7 percentage points above what was measured; low and high end bracket the measured number.
By their numbers in this assay, from the lowest: compounds 3, 1 and 2 (each within the scatter of the next, the first and the last beyond it).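

Going by these compounds alone, this is the first pair that differs in one place only, so the change from trifluoromethyl to phenyl on the aromatic carbon between two ring nitrogen atoms can now be read directly: in this assay it gives a number 5.2 percentage points lower from compound 1 to compound 3 (within the scatter). At this one position, then, a group with no ring and a larger group with a six-membered aromatic ring cannot be told apart at the one concentration tested. Nothing at hand explains this outcome or links it to a property of either group.

From the compounds shown here alone, it remains open whether an amine, a carboxylic acid or a longer chain on this same carbon would move the number beyond the scatter. A single pair also cannot show whether the same change would give a similar result on a different core.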